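Series notes: 3-fluorophenyl in place of 1,3-thiazol-2-yl

The source may hold more compounds than are shown below. What is called first, only, known or untested is meant among the compounds shown, and "the series" means these compounds.

Measured so far:
compound 1, `Cc1cc(C(=O)NCN2CCC(c3cccc[n+]3[O-])CC2)ccc1F` — 67%
compound 2, `Cc1cccc(NC(=O)CN2CCC(c3nccs3)CC2)c1` — 62%

Both compounds were read in a functional assay on HEK293 cells for agonist activity at D(4) dopamine receptor (Homo sapiens), read by FLIPR; a lower number here means a smaller maximal response, a higher number a larger maximal response. Compound 1 reaches 67% and compound 2 reaches 62%. On these two numbers compound 2 stands lowest, but its nearest neighbour, compound 1, lies within the scatter of it, so no order between the two can be claimed. Among the compounds with values here, the two measured compounds differ in more than one place, so no single step has been measured yet, and nothing is known about how any one change moves the largest response reached.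

Compound 3, `Cc1cccc(NC(=O)CN2CCC(c3cccc(F)c3)CC2)c1`, is the next compound to be measured in this assay. Against compound 2 the change is 3-fluorophenyl in place of 1,3-thiazol-2-yl on a saturated ring carbon.

Within the data shown here, no measured step speaks to this change. Among the measured compounds shown here, the expectation is therefore a step of no more than the scatter, in no particular direction, with the wider uncertainty that follows from having no precedent. The largest response of compound 3 in this assay is estimated at 62%, in a range from 45% to 80%. The step this estimate implies, no change at the digits printed from compound 2 to compound 3 (within the scatter), is expected to stay within the scatter.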

Compound 3, largest response reached (reported as efficacy), in percent of the reference or control that the assay uses: 40%
For compound 3 the middle estimate is 22 percentage points above the measured one; measured number below the stated range.
By their numbers in this assay, from the lowest: compound 3; then compounds 2 and 1 (each within the scatter of the next).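

Within the data shown here, the step at this saturated ring carbon is the first single change read: in this assay the move to 3-fluorophenyl from 1,3-thiazol-2-yl gives a number 22 percentage points lower from compound 2 to compound 3 (beyond the scatter) and so shows that the largest response reached depends on the aromatic ring held three ring bonds from the ring nitrogen. The change replaces a five-membered aromatic ring with 2 hetero atoms and 2 hydrogen-bond acceptors by a six-membered aromatic ring of carbon only with 0 hydrogen-bond acceptors, and it brings in fluorine as well, so this one step changes several features together and does not separate them. No measurement shown bears on the reason for this step.

The compounds shown leave open whether the lower response follows the loss of the 1,3-thiazol-2-yl ring or the fluorine on the new ring, a question that an unsubstituted phenyl at the same carbon would address. Also open, from the compounds shown here alone, is how a pyridin-2-yl or 1,3-oxazol-2-yl group at this place would read in this assay on the same core.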